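A few compounds are considered here, and "the series" means these few. Any claim that something is new, unique, unknown or untested is made for them only; others in the source may bear on it.

Compound 1 `CCN1C(=O)S/C(=C\C2=Cc3ccccc3OC2)C1=O` and compound 3 `CCN1C(=O)S/C(=C\C2=Cc3cccc(OC)c3OC2)C1=O` share one core. In a functional assay on MOLT-4 cells (Homo sapiens) for antiproliferative activity, read by MTT assay, with a stated time of 72 h (on this read-out higher numbers stand for weaker inhibition and lower numbers for stronger inhibition), compound 1 gives > 200000 nM, which is a limit of the assay rather than a number (the limit of > 200000 nM in this assay, at which 1 of the 3 values shown sits). Compound 3 gives 13200 nM in this assay. For the measured compounds named here, the single change between them, (methoxy in place of hydrogen on an aromatic carbon), produced an at least 15-fold lower number from compound 1 to compound 3 (1.18 log units; beyond the scatter).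

Compound 2 `O=C(O)CN1C(=O)/C(=C/C2=Cc3ccccc3OC2)SC1=S` has a second core; the difference between the two cores is not broken down here. In this assay compound 2 gives > 100000 nM, again a limit of the assay rather than a number (the limit of > 100000 nM in this assay, at which 1 of the 3 values shown sits).

Compound 4 `COc1cccc2c1OCC(/C=C1\SC(=S)N(CC(=O)O)C1=O)=C2` carries the same change on this second core, (methoxy in place of hydrogen on an aromatic carbon), the place matching word for word.

For compound 4 the expected step is an at least 5.0-fold lower number from compound 2 to compound 4 (0.69 log units; beyond the scatter), a size that rests on an at least 15-fold lower number from compound 1 to compound 3 (1.18 log units; beyond the scatter).

In this assay compound 4 is therefore estimated at 20000 nM, between 5000 nM and 100000 nM.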

Compound 4, half-maximal inhibitory concentration: > 200000 nM
Compound 4: a limit, no number (the forecaster's own chance of this, stated with the estimate: 30%); middle value at least 10-fold (1.00 log units) from the limit.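

For the compounds shown here, compound 2 and compound 4 both stand at limits of this assay, and no step from one to the other can be read. The compounds shown leave open whether methoxy in place of hydrogen changes anything on this second core.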